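A few compounds are considered here, and "the series" means these few. Any claim that something is new, unique, unknown or untested is made for them only; others in the source may bear on it.

Measured in a functional assay on MCF7 cells (Homo sapiens) for inhibition, read by MTT assay, with a stated time of 72 h; a lower number here means a stronger inhibitor, a higher number a weaker inhibitor:
- Compound 1 `CCCCc1ccc(NC(=O)C2CCN(C/C=C/c3ccccc3)CC2)cc1`: 5870 nM.
- Compound 2 `CCCCCc1ccc(NC(=O)C2CCN(C/C=C/c3ccccc3)CC2)cc1`: 3740 nM.
- Compound 3 `COc1ccc(NC(=O)C2CCN(C/C=C/c3ccccc3)CC2)cc1`: > 100000 nM, which is a limit of the assay and not a number.

Compound 3 stands at the limit of > 100000 nM in this assay, at which 1 of the 3 values shown sits. Compound 4 `O=C(Nc1ccccn1)C1CCN(C/C=C/c2ccccc2)CC1` has pyridin-2-yl in place of 4-methoxyphenyl on an amide-type nitrogen.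

Among the measured compounds shown here, no measured step makes this exact change. The closest are two large ones that replace a chain with methoxy, an at least 17-fold higher number from compound 1 to compound 3 (1.23 log units; beyond the scatter) and an at least 26-fold higher number from compound 2 to compound 3 (1.42 log units; beyond the scatter), while a 1.6-fold lower number from compound 1 to compound 2 (0.20 log units; within the scatter) lies within the scatter. Compound 4, like compound 3, has neither butyl nor pentyl, so no step beyond the scatter is expected in this assay, and a limit is the likeliest report. The expected change is an at least 1.4-fold lower number from compound 3 to compound 4 (0.15 log units; that floor lies within the scatter). The estimate for compound 4 is 70000 nM, with a range from 20000 nM to 100000 nM.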

Compound 4, half-maximal inhibitory concentration: 67200 nM
Compound 4: middle estimate off by 1.0-fold (0.02 log units), on the high side, within the range that was stated.
By their numbers in this assay, from the lowest: compounds 2 and 1 (each within the scatter of the next); then compound 4. At a limit, above all of these: compound 3.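

In this assay, among the compounds shown here, the ring on the amide-type nitrogen itself changes here, whereas the earlier compounds changed only a group carried on that ring, and the result is an at least 1.4-fold lower number from compound 3 to compound 4 (0.17 log units; that floor lies within the scatter). Compound 3 stands at a limit of the assay and not at a number: the limit of > 100000 nM in this assay, at which 1 of the 4 values shown sits. Pyridin-2-yl therefore gives a readable value with neither butyl nor pentyl present, but the true size of this step remains unknown.

The compounds shown leave open how pyridin-2-yl carrying a butyl chain would read. They also leave open what an amine or a carboxylic acid in place of methoxy would give.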